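A few compounds are considered here, and "the series" means these few. Any claim that something is new, unique, unknown or untested is made for them only; others in the source may bear on it.

Measured so far:
compound 1 `Cc1cccc(-n2cc(-c3cccc(NS(=O)(=O)c4c[nH]c(=O)[nH]c4=O)c3)nn2)c1` – 18500 nM
compound 2 `O=c1[nH]cc(S(=O)(=O)Nc2cccc(-c3cn(-c4ccc(F)cc4)nn3)c2)c(=O)[nH]1` – "not toxic" (no number reported)

Compound 1 has a number in an ADME assay on GES1 cells (Homo sapiens) for cytotoxicity, read by MTT assay, with a stated time of 24 h (a higher number here means that more compound is tolerated, a lower number that less compound is tolerated), while compound 2 was reported only in words there, so compound 2 stands without a figure to set against compound 1. Compound 3 `O=c1[nH]cc(S(=O)(=O)Nc2cccc(-c3cn(-c4ccc(Cl)cc4)nn3)c2)c(=O)[nH]1` differs from compound 2 by chloro in place of fluoro on an aromatic carbon. Going by the values given here, no measured pair shows what this exchange does here, so in this assay no shift beyond the usual scatter is expected in either direction. Compound 3 is therefore estimated to tolerate 30000 nM, within a range of 10000 nM to 100000 nM, and it may again be reported only as not toxic.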

Compound 3, half-maximal cytotoxic concentration: 11300 nM
For compound 3 the middle estimate is 2.7-fold (0.42 log units) above the measured one; the range from low to high includes it.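

In this assay, 4-chlorophenyl in place of 3-methylphenyl on an aromatic nitrogen gives a 1.6-fold lower number from compound 1 to compound 3 (0.21 log units; within the scatter), so this position accepts both groups with no difference beyond the scatter. From the compounds shown here alone, the step from compound 2 to compound 3 cannot be read, since compound 2 has only words, so the size of the exchange of fluoro for chloro stays unknown. No measured information explains this result.
Going by these compounds, whether an amine, a carboxylic acid or a longer chain in place of chloro would move the number beyond the scatter remains open.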